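This account rests on a few compounds, and the source may have more. Where it says the series, first, only, none or still open, it means among the compounds named here.

Compound 2 `Cc1ccc2[nH]c(=O)c(CN(CCCO)Cc3ccc(C(C)(C)C)cc3)cc2c1` is the starting point. In a toxicity assay on MDCK cells (Canis lupus familiaris) for cytotoxicity, read by crystal violet staining, with a stated time of 48 h (on this read-out higher numbers stand for lower toxicity in this test and lower numbers for higher toxicity in this test), compound 2 gives > 10000 nM, which is a limit of the assay rather than a measured number. Compound 3 `CCc1ccc2[nH]c(=O)c(CN(CCCO)Cc3ccc(C(C)(C)C)cc3)cc2c1` differs from compound 2 by methyl in place of hydrogen on a saturated chain carbon bound to an aromatic carbon. In this assay compound 3 gives > 10000 nM, again a limit. The step that the two limits leave unreadable from compound 2 to compound 3 therefore cannot be read. Compound 1 `Cc1ccc2cc(CN(Cc3ccc(Cl)cc3)Cc3ccc(Cl)cc3)c(=O)[nH]c2c1` gives > 33000 nM in this assay, also a limit. Compound 4 `Cc1ccc2[nH]c(=O)c(CN(Cc3ccc(C#N)cc3)Cc3ccc(C(C)(C)C)cc3)cc2c1` carries 4-cyanophenyl in place of 2-hydroxyethyl on a saturated chain carbon bound to an amine nitrogen. Every value shown sits at a limit, as the limit of > 10000 nM in this assay, at which 2 of the 3 values shown sit, and the limit of > 33000 nM in this assay, at which 1 of the 3 values shown sits, record, so no step beyond the scatter is expected. Compound 4 is expected to give about 15000 nM, within 5000 nM to 50000 nM. That estimate means a step that the limit leaves unreadable from compound 2 to compound 4 is expected.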

Compound 4, half-maximal cytotoxic concentration: > 5000 nM
Compound 4 was reported as a limit; the forecaster's own chance of this, stated with the estimate: 80%; the middle value is on the limit's open side.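

In this assay compound 4 gives > 5000 nM as a limit. Compound 2 gives > 10000 nM as a limit too, so no step can be read between these two compounds. The concentration at which any compound shown turns toxic stays open.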